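A few compounds are considered here, and "the series" means these few. Any claim that something is new, unique, unknown or untested is made for them only; others in the source may bear on it.

Among the measured compounds shown here, compound 3 `O=[N+]([O-])c1cc(C(F)(F)F)cc([N+](=O)[O-])c1Oc1c(Br)cc(Br)cc1/C=N\OCc1ccccc1Cl` gives 2450 nM in a functional assay on HepG2 cells (Homo sapiens) for antiproliferative activity, read by MTT assay, with a stated time of 48 h (on this read-out higher numbers stand for weaker inhibition and lower numbers for stronger inhibition), the highest of the three numbers so far, though the gap to compound 1 `O=[N+]([O-])c1cc(C(F)(F)F)cc([N+](=O)[O-])c1Oc1c(Br)cc(Br)cc1/C=N\OCc1ccccc1` at 1480 nM stays within the scatter, while compound 2 `O=[N+]([O-])c1cc(C(F)(F)F)cc([N+](=O)[O-])c1Oc1c(Br)cc(Br)cc1/C=N\OCc1ccccc1F` at 1100 nM sits further off. In steps: a 1.3-fold lower number from compound 1 to compound 2 (0.13 log units; within the scatter); a 1.7-fold higher number from compound 1 to compound 3 (0.22 log units; within the scatter); a 2.2-fold higher number from compound 2 to compound 3 (0.35 log units; beyond the scatter). Compound 4 `O=[N+]([O-])c1cc(C(F)(F)F)cc([N+](=O)[O-])c1Oc1c(Br)cc(Br)cc1/C=N/OCc1ccc(Cl)cc1Cl` differs from compound 3 in that (a group of 12 heavy atoms (8 carbon, 1 nitrogen, 1 oxygen, 2 chlorine; one six-membered aromatic ring of carbon only) in place of a group of 11 heavy atoms (8 carbon, 1 nitrogen, 1 oxygen, 1 chlorine; one six-membered aromatic ring of carbon only), on an aromatic carbon). For the measured compounds named here, the steps that bear on this are the two that brought chloro onto that ring, both of them pointing to a somewhat higher number, and a second chloro is expected to do little more than that, so for compound 4 the step expected is a 1.2-fold higher number from compound 3 to compound 4 (0.09 log units; within the scatter) in this assay. Compound 4 is therefore estimated at 3000 nM, with a range from 1500 nM to 6500 nM.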

Compound 4, half-maximal inhibitory concentration: 1050 nM
Beside the measured number, compound 4's estimate is 2.9-fold (0.46 log units) above it; the measured number lies below the stated range.
By their numbers in this assay, from the lowest: compounds 4, 2, 1 and 3 (each within the scatter of the next, the first and the last beyond it).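

In this assay, a second chloro on this ring does not extend the upward drift seen with the first chloro (a 2.3-fold lower number from compound 3 to compound 4 (0.37 log units; beyond the scatter)). Compound 4 instead stays within the scatter of the unsubstituted and fluoro compounds (a 1.4-fold lower number from compound 1 to compound 4 (0.15 log units; within the scatter); a 1.0-fold lower number from compound 2 to compound 4 (0.02 log units; within the scatter)), so the read-out does not rise with chloro count across these compounds. No measurement at hand accounts for this result.

Compound 4 also carries the opposite geometry at the double bond outside aromatic rings, so the second chloro and that geometry cannot be separated. On these data alone, how a methoxy group or an amine on this ring would behave remains open.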